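Adding a hydroxy group to compound 1

The source may report more compounds than this note shows. Statements on the series, on what has been measured and on what is new or still open speak of the compounds shown alone.

Compound 1 `COc1ccc(-c2c(Nc3ccc(C)cc3)c3ccccc3oc2=O)cc1`: 59400 nM
Compound 2 `COc1ccc(-c2c(Nc3ccc(NC(C)=O)cc3)c3ccccc3oc2=O)cc1`: > 100000 nM (a limit, not a number)
Compound 3 `COc1ccc(-c2c(Nc3cccc(C(F)(F)F)c3)c3ccccc3oc2=O)cc1`: 66400 nM

In a functional assay on HepG2 cells (Homo sapiens) for antiproliferative activity, read by MTT assay, with a stated time of 48 h (on this read-out higher numbers stand for weaker inhibition and lower numbers for stronger inhibition), compound 1 gives 59400 nM. It cannot be ranked against its nearest neighbour, since the data show a 1.1-fold higher number from compound 1 to compound 3 (0.05 log units; within the scatter). Compound 2 has no exact value, because its > 100000 nM is a limit of the assay.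

Compound 4 `COc1ccc(-c2c(Nc3ccc(C)cc3)c3ccc(O)cc3oc2=O)cc1` is compound 1 with a single change: hydroxy in place of hydrogen on an aromatic carbon, in a six-membered aromatic ring of carbon only that is part of a fused or bridged system of two rings (hydroxy in place of hydrogen on an aromatic carbon).

Among the measured compounds shown here, no measured step makes this change. The closest guides are changes elsewhere on compound 1: an at least 1.6-fold higher number from compound 1 to compound 2 (0.22 log units; that floor lies within the scatter), and the step to compound 3 given above. Neither shows a shift beyond the scatter, so they offer only a weak hint that single changes to compound 1 need not move the number much. They give no direction for a new hydroxy group, so no step beyond the scatter is expected, though the uncertainty is wide.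

The expected step is a 1.2-fold lower number from compound 1 to compound 4 (0.07 log units; within the scatter). For compound 4 the estimated value is 50000 nM, with an expected range from 22000 nM to 100000 nM.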

Compound 4, half-maximal inhibitory concentration: 88300 nM
Compound 4: the middle estimate sits 1.8-fold (0.25 log units) below what was measured; the range from low to high includes it.
By their numbers in this assay, from the lowest: compounds 1, 3 and 4 (each within the scatter of the next). At a limit, above all of these: compound 2.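

Among the compounds shown here, every single change to compound 1 seen so far lay on the aromatic group carried by the nitrogen, whereas compound 4 is the first to alter the shared core, on an aromatic carbon of the six-membered aromatic ring of carbon only that is part of a fused or bridged system of two rings. In this assay a hydroxy group on that carbon gives a 1.5-fold higher number from compound 1 to compound 4 (0.17 log units; within the scatter) and so produces no shift that can be told from the scatter, which means that compounds 1, 3 and 4 cannot be ranked and that this change brings no clear gain or loss. Compound 2 still cannot be placed against them, as it has a limit and not a number: the limit of > 100000 nM in this assay, at which 1 of the 4 values shown sits.

The compounds shown cannot say whether an amine or a carboxylic acid on this same carbon would read like the hydroxy group, or how a hydroxy group would read on the other carbons of this ring. From the compounds shown here alone, it also stays open whether any change on this ring could bring the number well below those of compounds 1, 3 and 4.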